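Hydroxy to methoxy: working notes on compound 3

The source may report more compounds than this note shows. Statements on the series, on what has been measured and on what is new or still open speak of the compounds shown alone.

Measured so far:
compound 1 `COc1cc(Cl)cc(-c2nn(-c3cccc(NC(=O)c4cccc(C(F)(F)F)c4)c3)cc2-c2ccncc2)c1`: 26%
compound 2 `O=C(Nc1cccc(-n2cc(-c3ccncc3)c(-c3cc(O)cc(Cl)c3)n2)c1)c1cc(C(F)(F)F)cc(C(F)(F)F)c1`: 20.4%

Among the compounds with values here, in a functional assay on K562 cells (Homo sapiens) for inhibition, read by sulforhodamine B assay, with a stated time of 48 h, tested at 10 uM (a lower number here means a stronger effect, a higher number a weaker effect of the compound at the concentration tested), compound 2 gives 20.4%, the lowest of the two numbers so far. Compound 1, which carries a methoxy group and a single trifluoromethyl group on its amide, gives 26% in this assay, a number that sits within the scatter of compound 2, so the two cannot be ranked. Compound 3 `COc1cc(Cl)cc(-c2nn(-c3cccc(NC(=O)c4cc(C(F)(F)F)cc(C(F)(F)F)c4)c3)cc2-c2ccncc2)c1` is not yet measured. Against compound 2 it differs in one place: methyl in place of hydrogen on an oxygen on an aromatic ring. Within the data shown here, no step between measured compounds isolates this change; compound 1 has the same methoxy group but also a different amide, so its value does not size it. The step of a number 2.6 percentage points higher from compound 2 to compound 3 (within the scatter) is therefore expected to fall within the scatter, in no clear direction. The estimate for compound 3 is 23%, in the range 10% to 38%.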

Compound 3, a percentage reported as activity, at one concentration (the size of the read-out at that concentration, not a potency): 38%
Beside the measured number, compound 3's estimate is 15 percentage points below it, within the range that was stated.
By their numbers in this assay, from the lowest: compounds 2 and 1 (each within the scatter of the next); then compound 3.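

Hydroxy to methoxy now has a measured size in this assay: a number 17.6 percentage points higher from compound 2 to compound 3 (beyond the scatter), which puts methyl on this oxygen on the weaker side at the concentration tested, with the amide of compound 2 held constant. With the 3-chloro-5-methoxyphenyl group held constant, the added trifluoromethyl moves the number the same way: a number 12 percentage points higher from compound 1 to compound 3 (beyond the scatter) in the same read-out. Within the data shown here, each of these two single changes thus gives a weaker effect, whereas the earlier pair differed in two places and gave no step.

The compounds shown leave open whether the hydroxy to methoxy step keeps its size on the amide of compound 1. They also leave open how an ethoxy group or an amine at this place would read.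

No measurement offered here accounts for either step.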